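Tetrazole to sulfoxide at the end of a chain

The source may report more compounds than this note shows. Statements on the series, on what has been measured and on what is new or still open speak of the compounds shown alone.

Compound 3 `CCc1cc(C(C)=O)c(O)cc1OCCCCCCC(C)(C)c1nnn[nH]1` gives 67% in an assay on isolated protein for binding affinity to leukotriene B4 receptor 1 (Homo sapiens), tested at 1 uM; on this read-out higher numbers stand for more inhibition at the one concentration tested (going by the name of the read-out) and lower numbers for less inhibition. Its number is the largest of the three, though compound 1 `CCc1cc(C(C)=O)c(O)cc1OCCCCC#N`, with 57%, lies within the scatter of it; compound 2 `CCc1cc(C(C)=O)c(O)cc1OCCCC(C)(C)C(=O)O`, with 43%, lies beyond. Compound 4 `CCc1cc(C(C)=O)c(O)cc1OCCCCCC[S+](C)[O-]` differs from compound 3 in one place: a group of 3 heavy atoms (1 carbon, 1 oxygen, 1 sulfur; no ring) in place of a group of 8 heavy atoms (4 carbon, 4 nitrogen; one five-membered aromatic ring with 4 hetero atoms), on a saturated chain carbon, six bonds along the chain from an oxygen on an aromatic ring. Going by the values given here, the only measured step touching a chain-end group is a number 14 percentage points lower from compound 1 to compound 2 (beyond the scatter), where a carboxylic acid replaced a nitrile. Compound 3 and compound 1 show that tetrazole and nitrile ends give numbers within scatter of each other. Nothing measured has a sulfoxide end, so a modest drop is expected in this assay, as a number 15 percentage points lower from compound 3 to compound 4 (beyond the scatter). Compound 4 is estimated at 52%, between 32% and 70%.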

Compound 4, a percentage reported as inhibition, at one concentration (the size of the read-out at that concentration, not a potency): 50%
For compound 4 the middle estimate is 2 percentage points above the measured one, within the range that was stated.
By their numbers in this assay, from the lowest: compounds 2, 4, 1 and 3 (each within the scatter of the next, the first and the last beyond it).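

In this assay the step to a sulfoxide end costs part of the tetrazole number, as a number 17 percentage points lower from compound 3 to compound 4 (beyond the scatter) shows, so this chain end does respond to the change. The sulfoxide end cannot be told apart from the other two ends, with a number 7 percentage points higher from compound 2 to compound 4 (within the scatter) and a number 7 percentage points lower from compound 1 to compound 4 (within the scatter). No measurement here explains these differences. Still open, from the compounds shown here alone, is whether the drop follows the tetrazole ring itself or the 1-methylethyl carbon carrying it. Also open, going by these compounds, is what a sulfone or an amine would give at this chain end.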